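Methyl on the amino nitrogen of compound 2

The compounds below may be only part of what the source reports. "The series", "measured", "known", "first", "only" and "open" are said of these compounds alone.

In a functional assay on OCI-Ly7 cells (Homo sapiens) for antiproliferative activity, read by WST assay, with a stated time of 3 days (on this read-out higher numbers stand for weaker inhibition and lower numbers for stronger inhibition), compound 1 `O=c1cc(I)n([C@@H]2O[C@H](CO)[C@@H](O)[C@H]2O)c(=O)[nH]1` gives > 50000 nM, which is a limit. Compound 2 `Nc1cc(=O)[nH]c(=O)n1[C@@H]1O[C@H](CO)[C@@H](O)[C@H]1O` gives > 50000 nM, also a limit, so it has no numerical potency to build on. Both compounds stand at the limit of > 50000 nM in this assay, at which 2 of the 2 values shown sit. Compound 3 `CNc1cc(=O)[nH]c(=O)n1[C@@H]1O[C@H](CO)[C@@H](O)[C@H]1O` differs from compound 2 by methyl in place of hydrogen on a nitrogen on an aromatic ring. Among the measured compounds shown here, the only measured step, a step that the two limits leave unreadable from compound 1 to compound 2, has no size to carry over, so no shift beyond the scatter is expected in this assay. The estimated step is a number no higher from compound 2 to compound 3 (the limit leaves the size open), and another limit is the likely report. For compound 3 the expected value is 50000 nM, with an estimated range of 10000 nM to 100000 nM.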

Compound 3, half-maximal inhibitory concentration: > 50000 nM
Compound 3 ended at the assay's limit; the forecaster's own chance of this, stated with the estimate: 80%; the middle value lies on the limit itself.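

Compound 3 gives > 50000 nM in this assay, which is a limit, so its steps from compound 1 and compound 2 cannot be read. The compounds shown leave open whether any substituent on this shared core gives a measurable potency in this assay.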